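A few compounds are considered here, and "the series" means these few. Any claim that something is new, unique, unknown or untested is made for them only; others in the source may bear on it.

Working notes on the series. In a functional assay on A549 cells (Homo sapiens) for cytotoxicity, read by MTT assay, with a stated time of 48 h (on this read-out higher numbers stand for weaker inhibition and lower numbers for stronger inhibition), compound 1 `COc1c(OCc2ncc(C)o2)cc(O)c2c(=O)cc(-c3ccccc3)oc12` reads > 100000 nM as a limit of the assay and not a number. Among the measured compounds shown here, compound 2 `COc1c(OCCCN2CCN(C)CC2)cc(O)c2c(=O)cc(-c3ccccc3)oc12` gives 9900 nM as the only true number so far, so there is no second measured value to place it against.

Compound 3 `COc1c(OCCCN2CCNCC2)cc(O)c2c(=O)cc(-c3ccccc3)oc12` departs from compound 2 at one place only, with hydrogen in place of methyl on an amine nitrogen in a ring as the counted difference: hydrogen in place of methyl on an amine nitrogen in a ring, turning 4-methylpiperazin-1-yl into piperazin-1-yl.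

For the measured compounds named here, the one measured step is an at least 10-fold lower number from compound 1 to compound 2 (1.00 log units; beyond the scatter) and it starts from the limit of > 100000 nM in this assay, at which 1 of the 2 values shown sits, so its true size stays open. That step exchanges a whole group and does not isolate the methyl, so it sets no size for the present change. Going by the values given here, no measured step touches this nitrogen. No step beyond the scatter is therefore expected in this assay in either direction, and the range is kept wide. The estimated change is a 1.1-fold lower number from compound 2 to compound 3 (0.04 log units; within the scatter) and is expected to lie within the scatter. For compound 3 the expected value is 9000 nM with an estimated range from 3500 nM to 25000 nM as the likely span.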

Compound 3, half-maximal inhibitory concentration: 10100 nM
Compound 3: middle estimate off by 1.1-fold (0.05 log units), on the low side; the measured number falls inside the stated range.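

In this assay, the step of a 1.0-fold higher number from compound 2 to compound 3 (0.01 log units; within the scatter) reads within the scatter, so hydrogen in place of methyl on this amine nitrogen leaves 4-methylpiperazin-1-yl and piperazin-1-yl not told apart on this read-out. Among the compounds shown here, this is the only measured step that isolates this nitrogen, whereas the earlier step exchanged a whole group and could not separate the methyl from the rest of the change. The step of an at least 9.9-fold lower number from compound 1 to compound 3 (0.99 log units; beyond the scatter) again exchanges a whole group, and its true size stays open because compound 1 stands at a limit and not a number: the limit of > 100000 nM in this assay, at which 1 of the 3 values shown sits.

Whether a larger group on this nitrogen, such as acetyl or benzyl, would also leave the number within the scatter stays open, since hydrogen and methyl are the only two cases shown here. Going by these compounds, it is also open whether the second ring nitrogen is needed at all, which morpholin-4-yl in place of piperazin-1-yl would test, and how a longer chain between the ring and the oxygen would read.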